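This account rests on a few compounds, and the source may have more. Where it says the series, first, only, none or still open, it means among the compounds named here.

Compound 1 `O=C(Nc1nc2ccc(Cl)cc2s1)c1cn(-c2ccccc2)nc1-c1ccccc1`: 21300 nM
Compound 2 `Cc1ccc2nc(NC(=O)c3cn(-c4ccccc4)nc3-c3ccccc3)sc2c1`: > 50000 nM

For the measured compounds named here, in an ADME assay on HEK-293T cells (Homo sapiens) for cytotoxicity, read by MTT assay, with a stated time of 72 h (a lower number here means a stronger inhibitor, a higher number a weaker inhibitor), compound 1 gives 21300 nM, the only plain number among the two values shown. For compound 2 the reading > 50000 nM is a limit of the assay rather than a number (the limit of > 50000 nM in this assay, at which 1 of the 2 values shown sits). Compound 3 `COc1ccc(-c2nn(-c3ccccc3)cc2C(=O)Nc2nc3ccc(Cl)cc3s2)cc1` differs from compound 1 by methoxy in place of hydrogen on an aromatic carbon. Going by the values given here, the one measured step, an at least 2.3-fold higher number from compound 1 to compound 2 (0.37 log units; beyond the scatter), changes a different ring of the shared core, so no measured step speaks to this change. Compound 3 is therefore expected to give 21000 nM, between 9000 nM and 50000 nM, an expected step of a 1.0-fold lower number from compound 1 to compound 3 (0.01 log units; within the scatter), nothing beyond the scatter.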

Compound 3, half-maximal inhibitory concentration: 12600 nM
Beside the measured number, compound 3's estimate is 1.7-fold (0.22 log units) above it; the measured number falls inside the stated range.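

In this assay, the change from phenyl to 4-methoxyphenyl, para to a large group, gives a 1.7-fold lower number from compound 1 to compound 3 (0.23 log units; within the scatter). For the compounds shown here, the only earlier step changed a different ring, so this is the first reading at this position, and here a methoxy leaves the number within the scatter. Nothing shown gives a cause for this step.

One group says little about the position as a whole. From the compounds shown here alone, whether an amine, a carboxylic acid or a longer chain in the same place would move the number beyond the scatter stays open.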